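Swapping cyclopropyl for tert-butyl on the nitrogen

A few compounds are considered here, and "the series" means these few. Any claim that something is new, unique, unknown or untested is made for them only; others in the source may bear on it.

- Compound 1 (`Cc1c(C)c2c(c(C)c1O)CCC(C)(/C=[N+](\[O-])C(C)(C)C)O2`) gives 5500 nM
- Compound 2 (`COc1c(C)c(C)c2c(c1C)CCC(C)(/C=[N+](\[O-])C(C)(C)C)O2`) gives 2940000 nM
- Compound 3 (`CC(=O)Oc1c(C)c(C)c2c(c1C)CCC(C)(/C=[N+](\[O-])C1CC1)O2`) gives 117000 nM

In a functional assay for inhibition, with Rattus norvegicus as the target (on this read-out lower numbers stand for stronger inhibition and higher numbers for weaker inhibition), compound 3 is the middle of the three, with a higher number than compound 1 and a lower one than compound 2. Compound 4 (`CC(=O)Oc1c(C)c(C)c2c(c1C)CCC(C)(/C=[N+](\[O-])C(C)(C)C)O2`) differs from compound 3 by tert-butyl in place of cyclopropyl on a double-bonded nitrogen. Within the data shown here, no measured step makes this swap. Among the measured compounds shown here, the only measured step, a 530-fold higher number from compound 1 to compound 2 (2.73 log units; beyond the scatter), is large, but it is methyl in place of hydrogen on an oxygen on an aromatic ring, so it bears only indirectly. Compound 4 keeps the oxygen substituent of compound 3, so no change beyond the scatter is expected in this assay. The estimated step is a 1.2-fold lower number from compound 3 to compound 4 (0.07 log units; within the scatter) and remains uncertain. For compound 4 the expected value is 100000 nM, with an estimated range from 20000 nM to 500000 nM for now.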

Compound 4, half-maximal inhibitory concentration: 895000 nM
The estimate for compound 4 lay 9.0-fold (0.95 log units) below the measured number; measured number outside the range, above it.
By their numbers in this assay, from the lowest: compound 1; then compound 3; then compound 4; then compound 2.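

In this assay, the group on the nitrogen matters: with acetyl held on the oxygen, tert-butyl in place of cyclopropyl gives a 7.6-fold higher number from compound 3 to compound 4 (0.88 log units; beyond the scatter) as its step. With tert-butyl on the nitrogen, the oxygen substituent also separates the compounds, through a 160-fold higher number from compound 1 to compound 4 (2.21 log units; beyond the scatter) for acetyl in place of hydrogen and a 3.3-fold lower number from compound 2 to compound 4 (0.52 log units; beyond the scatter) for acetyl in place of methyl, so hydrogen gives the lowest number and methyl the highest. Nothing available accounts for these differences. Going by these compounds, whether the nitrogen swap carries the same size with hydrogen or methyl on the oxygen remains open. So does the standing of isopropyl or a longer chain such as n-butyl on the nitrogen.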